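Fluorinated aryl swap on the cytotoxicity series

This account rests on a few compounds, and the source may have more. Where it says the series, first, only, none or still open, it means among the compounds named here.

Compound 3 `COc1cc2c(Oc3ccc(NC(=O)c4nccc(-c5ccc(C)cc5)n4)cc3F)ccnc2cc1OCCCN1CCN(C)CC1` gives "not determined" (no result reported) in a functional assay on A549 cells (Homo sapiens) for cytotoxicity, read by MTT assay, with a stated time of 72 h; a higher number here means a weaker inhibitor, a lower number a stronger inhibitor; it stands without a measured value. Compound 1 `COc1cc2c(Oc3ccc(NC(=O)c4nccc(-c5ccc(C)cc5)n4)cc3F)ccnc2cc1OCCCN1CCCCC1` gives 900 nM in this assay, and compound 2 `COc1cc2c(Oc3ccc(NC(=O)c4nccc(-c5ccc(F)cc5F)n4)cc3F)ccnc2cc1OCCCN1CCCCC1` gives 470 nM in this assay. Compound 4 `COc1cc2c(Oc3ccc(NC(=O)c4nccc(-c5ccc(F)cc5F)n4)cc3F)ccnc2cc1OCCCN1CCN(C)CC1` carries the same change applied to compound 3: 2,4-difluorophenyl in place of 4-methylphenyl on an aromatic carbon. Among the measured compounds shown here, the only measured step bearing on this swap is a 1.9-fold lower number from compound 1 to compound 2 (0.28 log units; within the scatter), a change that stays within the scatter. For the measured compounds named here, compounds 1 and 3 differ in a part of the molecule not varied between the measured pair, so no step anchors compound 3 itself. The expectation for compound 4 in this assay is therefore a value near that of compound 2, with no shift beyond the scatter. Compound 4 is estimated at 500 nM in this assay, with a range of 150 nM to 1700 nM.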

Compound 4, half-maximal inhibitory concentration: 660 nM
The estimate for compound 4 lay 1.3-fold (0.12 log units) below the measured number; low and high end bracket the measured number.
By their numbers in this assay, from the lowest: compounds 2, 4 and 1 (each within the scatter of the next).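

In this assay, the chain end gives its first readable step, a 1.4-fold higher number from compound 2 to compound 4 (0.15 log units; within the scatter), so 4-methylpiperazin-1-yl and piperidin-1-yl are not told apart with 2,4-difluorophenyl held fixed. The earlier compounds shown here gave no number with 4-methylpiperazin-1-yl, and the aryl swap on that chain end cannot be read, since compound 3 has no value. No supporting data bear on this result. Still open, on these data alone, is whether morpholine at the chain end, or a longer chain, would stay in this range. A 4-chlorophenyl group at the aryl position is equally untested in these compounds.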